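Working notes: from compound 2 to compound 3

This account rests on a few compounds, and the source may have more. Where it says the series, first, only, none or still open, it means among the compounds named here.

Measured so far:
compound 1, `COc1ccc([C@@H]2C/C(=N\O)c3c(O)cc(OCc4cn(Cc5ccccc5Cl)nn4)cc3O2)cc1O`, 13400 nM
compound 2, `COc1ccc([C@@H]2CC(=O)c3c(O)cc(OCc4cn(Cc5ccccc5)nn4)cc3O2)cc1O`, 11000 nM

In a functional assay on RAW264.7 cells (Mus musculus) for inhibition, read by Griess assay, with stated times of 2 h and 24 h (a higher number here means a weaker inhibitor, a lower number a stronger inhibitor), compound 2 gives 11000 nM. In this assay compound 1 gives 13400 nM, and the two numbers lie within the scatter of each other, so neither compound stands apart from the other on what has been measured.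

Compound 3, `COc1ccc([C@@H]2CC(=O)c3c(O)cc(OCc4cn(C5CCCCC5)nn4)cc3O2)cc1O`, is not yet measured. It differs from compound 2 in one place: cyclohexyl in place of benzyl on an aromatic nitrogen. For the measured compounds named here, no pair of measured compounds differs in a single place, so there is no measured step to lean on; the only comparison available is compound 1 against compound 2, and those two numbers do not separate.

The change is expected to give no step beyond the scatter, a 1.1-fold higher number from compound 2 to compound 3 (0.04 log units; within the scatter). Compound 3 is expected to give 12000 nM in this assay, with a range from 5000 nM to 30000 nM.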

Compound 3, half-maximal inhibitory concentration: 15600 nM
The estimate for compound 3 lay 1.3-fold (0.11 log units) below the measured number; the measured number falls inside the stated range.
By their numbers in this assay, from the lowest: compounds 2, 1 and 3 (each within the scatter of the next).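

Cyclohexyl in place of benzyl on the aromatic nitrogen of the five-membered ring gives the first step at a single place in this series, a 1.4-fold higher number from compound 2 to compound 3 (0.15 log units; within the scatter), in this assay. A non-aromatic six-membered carbon ring therefore leaves the number within the scatter of the benzyl compound, so the aromatic ring of the benzyl group is not required to keep activity at the level of compound 2 in this assay. No measured evidence bears on why the two groups do not separate.

The compounds shown leave open whether any group on this nitrogen can move the number beyond the scatter, for instance a substituent carrying an amine or a carboxylic acid, or a longer alkyl chain. They also leave the carbonyl of the shared core untested as a single change, since compound 1 differs from compound 2 in more than one place.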